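Hydroxy Added to a Cytotoxic Diterpenoid Lactone Core

A few compounds are considered here, and "the series" means these few. Any claim that something is new, unique, unknown or untested is made for them only; others in the source may bear on it.

Compound 1 `CO[C@H]1OC[C@]2(C)CCC[C@]3(COC(=O)[C@@]45C[C@@H](CC[C@H]43)[C@H](C)C5=O)[C@H]12` in a functional assay on K562 cells (Homo sapiens) for cytotoxicity, read by MTT assay; a lower number here means a stronger inhibitor, a higher number a weaker inhibitor: compound 1 gives a limit, > 50 ug/mL.
Compound 2 `CO[C@H]1OC[C@]2(C)CCC[C@]3(COC(=O)[C@@]45C[C@@H](CC[C@H]43)[C@@H](C)C5=O)[C@H]12`: compound 2 gives a limit, > 50 ug/mL.
Compound 3 `C=C1C(=O)[C@]23C[C@H]1CC[C@H]2[C@@]1(CCC[C@@]2(C)CO[C@@H](OC)[C@H]21)COC3=O`: compound 3 gives 0.18 ug/mL.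

For the measured compounds named here, compound 3 holds the only real number among the three; the other two values are limits. Compound 4 `C=C1C(=O)[C@]23C[C@H]1C[C@@H](O)[C@H]2[C@@]1(CCC[C@@]2(C)CO[C@@H](OC)[C@H]21)COC3=O` differs from compound 3 by hydroxy in place of hydrogen on a saturated ring carbon. Going by the values given here, the only measured step, a step that the two limits leave unreadable from compound 1 to compound 2, concerns a change of configuration alone and is unreadable owing to the limit of > 50 ug/mL in this assay, at which 2 of the 3 values shown sit, so no measured step speaks to a hydroxy entering here. With nothing to guide the direction, compound 4 is expected to stay within the usual scatter of compound 3, with the step of a 1.7-fold higher number from compound 3 to compound 4 (0.22 log units; within the scatter) expected to be small. Compound 4 is therefore estimated at 0.3 ug/mL, within 0.1 ug/mL to 1 ug/mL.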

Compound 4, half-maximal inhibitory concentration: 0.87 ug/mL
Compound 4: middle estimate off by 2.9-fold (0.46 log units), on the low side; measured number inside the range.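

In this assay, hydroxy in place of hydrogen on this saturated ring carbon gives the only readable step among the compounds shown, a 4.8-fold higher number from compound 3 to compound 4 (0.68 log units; beyond the scatter). The position therefore accepts the hydroxy with a modest weakening, and the change does not take the value to a limit; the earlier step between the two limits cannot be read. Nothing measured here gives a reason for this loss. On these data alone, whether a methoxy, an amine or a fluorine on this carbon would behave as hydroxy does stays open. So does the effect of the opposite configuration of the hydroxy.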